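A few compounds are considered here, and "the series" means these few. Any claim that something is new, unique, unknown or untested is made for them only; others in the source may bear on it.

Working notes on the series.

In an assay on CHO cells with 5-hydroxytryptamine receptor 1B (Homo sapiens) as the target (on this read-out higher numbers stand for weaker inhibition and lower numbers for stronger inhibition), compound 1 `CN(CC(C)(C)C)CC1(O)CCN(CCCc2c[nH]c3ccc(-n4cnnc4)cc23)CC1` gives 61 nM. Going by the values given here, this is the lowest of the two numbers measured so far; the nearest is compound 2 `CN(Cc1ccccc1)CC1(O)CCN(CCCc2c[nH]c3ccc(-n4cnnc4)cc23)CC1`, which in this assay gives 96 nM, so the two lie within the scatter of each other and no order between them can be read.

Compound 3 `Cc1ccccc1CN(C)CC1(O)CCN(CCCc2c[nH]c3ccc(-n4cnnc4)cc23)CC1` has not yet been measured in this assay. It differs from compound 1 in one place: 2-methylphenyl in place of tert-butyl on a saturated chain carbon bound to an amine nitrogen.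

Among the compounds with values here, the one measured step that bears on this change is a 1.6-fold higher number from compound 1 to compound 2 (0.20 log units; within the scatter), where phenyl took the place of tert-butyl on the same saturated chain carbon bound to an amine nitrogen. Compound 3 carries the same kind of change with an added methyl on the ring, for which nothing has been measured in the series. On this basis the step of a 1.6-fold higher number from compound 1 to compound 3 (0.21 log units; within the scatter) is expected to stay within the scatter, with no direction claimed. For compound 3 the estimated value in this assay is 100 nM, with a range from 45 nM to 220 nM.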

Compound 3, half-maximal inhibitory concentration: 89 nM
Beside the measured number, compound 3's estimate is 1.1-fold (0.05 log units) above it; the measured number falls inside the stated range.
By their numbers in this assay, from the lowest: compounds 1, 3 and 2 (each within the scatter of the next).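

In this assay, the methyl on the ring now has a reading of its own: a 1.1-fold lower number from compound 2 to compound 3 (0.03 log units; within the scatter) shows that methyl in place of hydrogen on an aromatic carbon leaves no readable mark on this pair. The full exchange of 2-methylphenyl in place of tert-butyl on a saturated chain carbon bound to an amine nitrogen gives a 1.5-fold higher number from compound 1 to compound 3 (0.16 log units; within the scatter), so a group of 7 heavy atoms with a six-membered aromatic ring, entering for one of 4 heavy atoms with no ring, also produces no step beyond the scatter, and compound 1, compound 2 and compound 3 cannot be ordered. Nothing available offers an explanation for this flat reading at the position.

The compounds shown leave open whether a ring carrying a methoxy group or a chlorine, or a pyridine ring in place of the phenyl, would stay within the scatter of these three. Also open, as far as these compounds go, is whether an amine or a carboxylic acid on this group would give a step beyond the scatter, as every step read so far at this place lies within it.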